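Imine nitrogen substituents and paw edema inhibition

This account rests on a few compounds, and the source may have more. Where it says the series, first, only, none or still open, it means among the compounds named here.

Compound 3 `N#Cc1c2n(c(=O)n(-c3ccccc3)/c1=N\CCO)CCC2` gives 5.6% in a functional assay on the whole organism (strain albino) for inhibition, with Rattus norvegicus as the target, read by paw edema, with a stated time of 1 h, at a dose of 0.029 mmol/kg by the oral route (a higher number here means more inhibition at the dose given (going by the name of the read-out), a lower number less inhibition), the lowest of the three numbers, with compound 2 `CC/N=c1/c(C#N)c2n(c(=O)n1-c1ccccc1)CCC2` at 7.82% within the scatter of it and compound 1 `C/N=c1/c(C#N)c2n(c(=O)n1-c1ccccc1)CCC2` at 19.1% beyond it. The step to compound 4 `C=CC/N=c1/c(C#N)c2n(c(=O)n1-c1ccccc1)CCC2` is vinyl in place of hydroxymethyl on a saturated chain carbon bound to a double-bonded nitrogen. Among the measured compounds shown here, two measured steps bear on it: a number 11.3 percentage points lower from compound 1 to compound 2 (beyond the scatter) and a number 13.5 percentage points lower from compound 1 to compound 3 (beyond the scatter) both show that adding a group at this carbon costs a modest amount, while a number 2.2 percentage points lower from compound 2 to compound 3 (within the scatter) shows that the hydroxy itself changes little. Vinyl keeps the chain roughly as long as in compound 2 and compound 3, so no step beyond the scatter is expected from compound 3; the expected step is a number 2.4 percentage points higher from compound 3 to compound 4 (within the scatter). For compound 4 the expected value in this assay is 8%, with a range from 0% to 20%, resting on compound 2 giving 7.82% with a comparable chain.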

Compound 4, a percentage reported as inhibition, in the whole organism at one dose (the size of the read-out at that dose, not a potency): 2.23%
Compound 4: the middle estimate sits 5.8 percentage points above what was measured; measured number inside the range.
By their numbers in this assay, from the lowest: compounds 4, 3 and 2 (each within the scatter of the next); then compound 1.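

In this assay, vinyl in place of hydroxymethyl gives a number 3.4 percentage points lower from compound 3 to compound 4 (within the scatter) and vinyl in place of methyl gives a number 5.6 percentage points lower from compound 2 to compound 4 (within the scatter), so a third group at this carbon still does not separate from the other two, even with the hydrogen-bond donor and acceptor of the 2-hydroxyethyl chain gone in the allyl chain. Vinyl in place of hydrogen gives a number 16.9 percentage points lower from compound 1 to compound 4 (beyond the scatter), which makes compound 4 the third compound, with compound 2 and compound 3, to lie beyond the scatter of compound 1, and so far methyl alone on the double-bonded nitrogen stands apart. No measurement available here accounts for this pattern. From the compounds shown here alone, whether an amine, a carboxylic acid or a longer chain at this carbon would also stay with compound 2, compound 3 and compound 4 remains open. Going by these compounds, how the compounds compare at other oral doses or later times also remains open.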